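The source may report more compounds than this note shows. Statements on the series, on what has been measured and on what is new or still open speak of the compounds shown alone.

Measured compounds in a functional assay on BXPC-3 cells (Homo sapiens) for inhibition, read by MTT assay, with a stated time of 7 days; a higher number here means a weaker inhibitor, a lower number a stronger inhibitor:
Compound 1 `O=C([C@@H]1CCCN(S(=O)(=O)c2ccc(S(=O)(=O)C3CCC3)cc2)C1)N1CCC(F)(F)CC1` — 78 nM
Compound 2 `O=C([C@@H]1CCCN(S(=O)(=O)c2ccc(S(=O)(=O)C3COC3)cc2)C1)N1CCC(F)(F)CC1` — 361 nM
Compound 3 `CCN(CC)C(=O)c1ccc(S(=O)(=O)N2CCC[C@@H](C(=O)N3CCC(F)(F)CC3)C2)cc1` — 240 nM

Within these three, compound 3 stands second highest in this assay; its number is within the scatter of compound 2, while its step from compound 1 is a 3.1-fold higher number from compound 1 to compound 3 (0.49 log units; beyond the scatter), beyond the scatter. Compound 4 `O=C([C@@H]1CCCN(S(=O)(=O)c2ccc(S(=O)(=O)C3CC3)cc2)C1)N1CCC(F)(F)CC1` differs from compound 3 in one place: cyclopropylsulfonyl in place of diethylcarbamoyl on an aromatic carbon.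

Among the compounds with values here, two measured steps bear on this change. The step of a 3.1-fold higher number from compound 1 to compound 3 (0.49 log units; beyond the scatter) shows that exchanging a cyclobutylsulfonyl for a diethylcarbamoyl on that aromatic carbon raised the number modestly; the step from compound 3 to compound 4 largely reverses that exchange, with a three-membered ring of carbon only in place of the four-membered one. The step of a 4.6-fold higher number from compound 1 to compound 2 (0.67 log units; beyond the scatter) shows that a small change within the sulfonyl substituent can itself move the number modestly, so the reversal need not be exact.

On this basis the number for compound 4 is expected to fall modestly, by about a 2.2-fold lower number from compound 3 to compound 4 (0.34 log units; beyond the scatter), toward that of compound 1. The estimate for compound 4 in this assay is 110 nM, with a range from 40 nM to 300 nM.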

Compound 4, half-maximal inhibitory concentration: 129 nM
Compound 4: middle estimate off by 1.2-fold (0.07 log units), on the low side, and the stated range covers the measured number.
By their numbers in this assay, from the lowest: compounds 1, 4, 3 and 2 (each within the scatter of the next, the first and the last beyond it).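

In this assay, cyclopropylsulfonyl and diethylcarbamoyl on this aromatic carbon cannot be told apart (a 1.9-fold lower number from compound 3 to compound 4 (0.27 log units; within the scatter)), although cyclobutylsulfonyl and diethylcarbamoyl could. On the sulfonyl sulfur, the three-membered and four-membered carbon rings also fall within the scatter of each other (a 1.7-fold higher number from compound 1 to compound 4 (0.22 log units; within the scatter)), while the oxetan-3-yl group stands apart from the cyclopropyl group (a 2.8-fold lower number from compound 2 to compound 4 (0.45 log units; beyond the scatter)), as it does from the cyclobutyl group, so among these three sulfonyl substituents only the ring holding oxygen gives a clearly higher number. Nothing shown offers a measured reason for these steps.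

The compounds shown leave open how an open-chain substituent such as methyl or isopropyl on the sulfonyl sulfur would compare. They also leave open whether a larger carbon ring such as cyclopentyl, or a ring holding an amine nitrogen such as azetidin-3-yl, would fit the same picture.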